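The compounds below may be only part of what the source reports. "The series", "measured", "known", "first", "only" and "open" are said of these compounds alone.

Compound 1, whose structure is `COc1cc(-c2nn(-c3cccc(NC(=O)Nc4ccc(Cl)c(Cl)c4)c3)cc2-c2ccncc2)ccc1Cl`, returns only a limit in a functional assay on OVCAR-5 cells (Homo sapiens) for inhibition, read by sulforhodamine B assay, with a stated time of 48 h; a lower number here means a stronger inhibitor of growth, a higher number a weaker inhibitor of growth: compound 1 gives > 50000 nM, which is the assay's upper bound and not a number. Compound 2, `O=C(Nc1cccc(-n2cc(-c3ccncc3)c(-c3ccc(Cl)c(O)c3)n2)c1)Nc1ccc(Cl)c(Cl)c1`, differs from compound 1 by hydrogen in place of methyl on an oxygen on an aromatic ring, and compound 2 likewise gives only a limit, > 32500 nM. The step that the two limits leave unreadable from compound 1 to compound 2 therefore cannot be read, since both ends sit at the limit of > 50000 nM in this assay, at which 1 of the 3 values shown sits, and (the limit of > 32500 nM in this assay, at which 1 of the 3 values shown sits). Going by the values given here, compound 3, `O=C(Nc1cccc(-n2cc(-c3ccncc3)c(-c3ccc(Cl)c(O)c3)n2)c1)Nc1cc(C(F)(F)F)cc(C(F)(F)F)c1`, is the one compound with a number in this assay, where compound 3 gives 2030 nM. Compound 4, `COc1cc(-c2nn(-c3cccc(NC(=O)Nc4ccc(Cl)c(C(F)(F)F)c4)c3)cc2-c2ccncc2)ccc1Cl`, carries the change (trifluoromethyl in place of chloro on an aromatic carbon), trifluoromethyl in place of chloro on an aromatic carbon, ortho to a chloro group and meta to a large group. No measured step matches this change, and the only step shown is unreadable, so the expectation for compound 4 rests on compound 3 alone. Compound 4 is expected to give 30000 nM, within 5000 nM to 100000 nM, an estimated step of an at least 1.6-fold lower number from compound 1 to compound 4 (0.22 log units; that floor lies within the scatter).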

Compound 4, concentration for total growth inhibition: 11000 nM
Beside the measured number, compound 4's estimate is 2.7-fold (0.44 log units) above it; low and high end bracket the measured number.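

Trifluoromethyl in place of chloro on an aromatic carbon, ortho to a chloro group and meta to a large group, gives the first readable step in this part of the series, an at least 4.5-fold lower number from compound 1 to compound 4 (0.65 log units; beyond the scatter), in this assay. The change thus turns the 3,4-dichlorophenyl end of compound 1 into a 4-chloro-3-(trifluoromethyl)phenyl end that gives a number and not a limit, so this position responds to what it carries. The step is only a floor, because compound 1 stands at a limit of the assay and not at a number: the limit of > 50000 nM in this assay, at which 1 of the 4 values shown sits.

The compounds shown leave open whether the same change would have a similar effect with a hydroxy group in place of the methoxy group. They also leave open how a nitrile, a methyl group or an amine at this position would compare with trifluoromethyl.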